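A few compounds are considered here, and "the series" means these few. Any claim that something is new, unique, unknown or untested is made for them only; others in the source may bear on it.

Of the compounds shown here, two have been read in an ADME assay on Vero cells (Chlorocebus sabaeus) for cytotoxicity, read by MTT assay; on this read-out lower numbers stand for higher toxicity in this test and higher numbers for lower toxicity in this test. Compound 1 `CCCCCCC#Cc1cn([C@@H]2O[C@H](CO)[C@@H](O)[C@H]2O)c(=O)[nH]c1=O` gives 111000 nM in this assay and stands as the lower of the two numbers. Compound 2 `O=c1[nH]cc(C#CC(O)c2ccccc2)c(=O)[nH]1` gives 242000 nM in this assay, a higher number, and the gap to compound 1 lies beyond the scatter. Compound 3 `O=c1[nH]c(=O)n([C@@H]2O[C@H](CO)[C@@H](O)[C@H]2O)cc1C#Cc1ccccc1` has not yet been measured. Against compound 1 it carries phenyl in place of hexyl on a triple-bonded carbon. Among the measured compounds shown here, no step between measured compounds isolates this change, so its size is open; compound 2 also carries a phenyl on its triple-bonded carbon and gives the higher number, but it differs from compound 1 in other places too. The step of a 1.4-fold higher number from compound 1 to compound 3 (0.16 log units; within the scatter) is expected to be small, a modest rise at about the edge of the scatter. Compound 3 is accordingly estimated at 160000 nM in this assay, with a range from 60000 nM to 420000 nM.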

Compound 3, half-maximal cytotoxic concentration: 78400 nM
Beside the measured number, compound 3's estimate is 2.0-fold (0.31 log units) above it; low and high end bracket the measured number.
By their numbers in this assay, from the lowest: compounds 3 and 1 (each within the scatter of the next); then compound 2.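

In this assay, the change from hexyl to phenyl on a triple-bonded carbon can now be read on its own, and a 1.4-fold lower number from compound 1 to compound 3 (0.15 log units; within the scatter) is the step it gives. At this position, an open chain and an aromatic ring of the same heavy-atom count are therefore not told apart by this read-out, at least for this one pair on the core of compound 1. No measured evidence is available that would explain this result.

Going by these compounds, whether a longer chain, an amine or a carboxylic acid on the same triple-bonded carbon would give a step beyond the scatter remains open. Compound 2 differs from compound 1 and compound 3 in more than one place, so the compounds shown do not isolate the source of its higher number.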